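A few compounds are considered here, and "the series" means these few. Any claim that something is new, unique, unknown or untested is made for them only; others in the source may bear on it.

Working notes on the series. Among the compounds with values here, in a functional assay, read by spectrophotometry, with a stated time of 2 h (on this read-out lower numbers stand for stronger inhibition and higher numbers for weaker inhibition), compound 1 (`CC(C)[C@@H]1CC[C@@H](C)C[C@@]12N(C)C(=O)[C@@H]1[C@H]3C(=O)N(c4ccccc4)C(=O)[C@H]3ON12`) gives 2310 ug/mL and compound 2 (`CC(C)[C@@H]1CC[C@@H](C)C[C@@]12N(C)C(=O)[C@@H]1[C@H]3C(=O)N(c4ccc(Cl)cc4)C(=O)[C@H]3ON12`) gives 710 ug/mL, the lower of the only two numbers available. Within the data shown here, the one measured step is a 3.3-fold lower number from compound 1 to compound 2 (0.51 log units; beyond the scatter), with chloro in place of hydrogen on an aromatic carbon.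

Next is compound 3 (`Cc1cccc(N2C(=O)[C@H]3[C@H](ON4[C@@H]3C(=O)N(C)[C@@]43C[C@H](C)CC[C@H]3C(C)C)C2=O)c1`), and the change is 3-methylphenyl in place of 4-chlorophenyl on an amide-type nitrogen in a ring. In words, this is 3-methylphenyl in place of 4-chlorophenyl on an amide-type nitrogen in a ring. Among the measured compounds shown here, no measured compound carries the 3-methylphenyl group, so the data offer no direct step for it. For the measured compounds named here, compound 3 does lack the chloro, and the only relevant guide is the step of a 3.3-fold lower number from compound 1 to compound 2 (0.51 log units; beyond the scatter). Part or all of that step is therefore expected to be given back, which points to a modest move toward a higher number in this assay, meaning weaker inhibition. The expected size of the move is a 2.1-fold higher number from compound 2 to compound 3 (0.32 log units; beyond the scatter). For compound 3 the estimated value is 1500 ug/mL, with an expected range of 650 ug/mL to 3500 ug/mL.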

Compound 3, half-maximal inhibitory concentration: 1930 ug/mL
Compound 3: the middle estimate sits 1.3-fold (0.11 log units) below what was measured, within the range that was stated.
By their numbers in this assay, from the lowest: compound 2; then compounds 3 and 1 (each within the scatter of the next).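

In this assay, exchanging 4-chlorophenyl for 3-methylphenyl on the amide-type nitrogen gives a 2.7-fold higher number from compound 2 to compound 3 (0.43 log units; beyond the scatter), so the lower number seen with the chloro does not carry over to this methyl-bearing group of the same size in heavy atoms. Taken on its own, the methyl of the 3-methylphenyl group gives a 1.2-fold lower number from compound 1 to compound 3 (0.08 log units; within the scatter), so this methyl leaves no readable change, and of the three compounds only compound 2, at 710 ug/mL, stands apart beyond the scatter from both others. Nothing at hand accounts for the different outcomes of the chloro and the methyl.

The 4-chlorophenyl and 3-methylphenyl groups differ both in the substituent and in where it sits on the aromatic ring, so the compounds shown cannot separate the effect of the chloro itself from that of its placement. On these data alone, how a nitrile, a methoxy group or a carboxylic acid would read on this aromatic ring remains open, as does whether the step seen with the chloro holds with any change elsewhere on the shared core.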